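Chain growth at the ring nitrogen of the shared core

The compounds below may be only part of what the source reports. "The series", "measured", "known", "first", "only" and "open" are said of these compounds alone.

Compound 1 `CC(C)Nc1ncc(-c2cccc(Cl)c2)c(-c2ccccc2)n1` gives 71% in an assay on CHO cells for displacement of a labelled ligand from adenosine receptor A1 (Homo sapiens), read by scintillation counting, with a stated time of 1 h, tested at 1 uM; a higher number here means more inhibition at the concentration tested (going by the name of the read-out), a lower number less inhibition. Among the measured compounds shown here, compound 2 `C#CCNc1ncc(-c2cccc(Cl)c2)c(-c2ccccc2)n1` gives 76% in this assay, a step of a number 5 percentage points higher from compound 1 to compound 2 (within the scatter), so compound 2 sits within the scatter of compound 1 and is the higher of only two numbers. Compound 3 `Clc1cccc(-c2cnc(NCCCc3ccccc3)nc2-c2ccccc2)c1` differs by phenethyl in place of ethynyl on a saturated chain carbon bound to a nitrogen on an aromatic ring. For the measured compounds named here, the single measured step exchanged small chains and stayed within the scatter; no step adds a ring here, so compound 3 is expected near compound 2 with a step of a number 8 percentage points lower from compound 2 to compound 3 (within the scatter), estimated at 68% between 40% and 90%.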

Compound 3, a percentage reported as inhibition, at one concentration (the size of the read-out at that concentration, not a potency): 33%
Compound 3: the middle estimate sits 35 percentage points above what was measured; the whole stated range lies above it.
By their numbers in this assay, from the lowest: compound 3; then compounds 1 and 2 (each within the scatter of the next).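

Exchanging isopropyl for 3-phenylpropyl on a nitrogen on an aromatic ring gives a number 38 percentage points lower from compound 1 to compound 3 (beyond the scatter) and exchanging propargyl for 3-phenylpropyl gives a number 43 percentage points lower from compound 2 to compound 3 (beyond the scatter) in this assay and so marks a clear loss. This position, unchanged within the scatter across the two small chains, does respond once the chain is longer and carries a six-membered aromatic ring. Nothing available explains the fall.

Compound 3 changes chain length and adds the ring in one step, so the two stay unseparated. A benzyl group, a plain butyl chain or a chain ending in an amine could tell them apart.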